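Hydroxy for Chloro Carried onto a Second Core

A few compounds are considered here, and "the series" means these few. Any claim that something is new, unique, unknown or untested is made for them only; others in the source may bear on it.

Compound 1, `N#Cc1c(-c2ccc(Cl)cc2)nc(SCC(=O)Nn2c(COc3ccc(Cl)cc3Cl)nc3ccccc3c2=O)[nH]c1=O`: 64.9%
Compound 2, `N#Cc1c(-c2ccc(O)cc2)nc(SCC(=O)Nn2c(COc3ccc(Cl)cc3Cl)nc3ccccc3c2=O)[nH]c1=O`: 68.4%
Compound 3, `N#Cc1c(Nc2ccc(Cl)cc2)nc(SCC(=O)Nn2c(COc3ccc(Cl)cc3Cl)nc3ccccc3c2=O)nc1-c1ccccc1`: 59.7%

All three measured compounds were tested in a functional assay on the whole organism (strain albino) for inhibition, with Rattus norvegicus as the target, read by paw edema, with stated times of 1 h and 3 h, at a dose of 100 mg/kg by the oral route; a higher number here means a stronger effect of the compound at the dose given, a lower number a weaker effect. Compound 1 and compound 2 share one core and differ in a single place: hydroxy in place of chloro on an aromatic carbon. In this assay that change gave a number 3.5 percentage points higher from compound 1 to compound 2 (within the scatter), so the two values are within the usual scatter of each other and no order between them can be read.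

Compound 3 is built on a second core; how the core of compound 3 differs from the core of compound 1 is not broken down here. In this assay compound 3 gives 59.7%, a number that lies within the scatter of both compound 1 and compound 2, so the three measured compounds are not separated by this assay.

Compound 4, `N#Cc1c(Nc2ccc(O)cc2)nc(SCC(=O)Nn2c(COc3ccc(Cl)cc3Cl)nc3ccccc3c2=O)nc1-c1ccccc1`, has not yet been measured in this assay. It differs from compound 3 by hydroxy in place of chloro on an aromatic carbon. The place of this change reads the same, word for word, as the place of the change from compound 1 to compound 2, so the same change is now made on the second core. Compound 4 is expected to sit close to compound 3, and this expectation rests on compound 1 and compound 2, whose change gave a number 3.5 percentage points higher from compound 1 to compound 2 (within the scatter). The step now expected is a number 3.3 percentage points higher from compound 3 to compound 4 (within the scatter). Compound 4 is therefore estimated at 63% in this assay, with the likely range running from 51% to 75%.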

Compound 4, a percentage reported as inhibition, in the whole organism at one dose (the size of the read-out at that dose, not a potency): 59.7%
Beside the measured number, compound 4's estimate is 3.3 percentage points above it; the measured number falls inside the stated range.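

In this assay, placing hydroxy where chloro stood on the core of compound 3 gave a step that reads no change at the digits printed from compound 3 to compound 4 (within the scatter). Set beside the same change on the core of compound 1, the two steps do not differ beyond what repeated measurement allows: the same change on two cores in this assay, a number 3.5 percentage points higher (within the scatter) from compound 1 to compound 2 and no change at the digits printed (within the scatter) from compound 3 to compound 4, 3.5 percentage points apart, within the scatter of two such steps. So, as far as this read-out at a single dose can tell, the change behaved alike on both cores, with neither step standing clear of the scatter; this does not show that the change is without effect, that the two cores respond identically, or that an effect smaller than the scatter is absent, and each step rests on a single pair of compounds.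

The compounds shown leave open whether another group at the same place, such as methoxy, an amine or a carboxylic acid, would stand apart from chloro and hydroxy in this assay. They also leave open whether the change from 4-chlorophenyl to 4-hydroxyphenyl, or from (4-chlorophenyl)amino to (4-hydroxyphenyl)amino, would read the same way at other doses or on any further core.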